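Aryl in place of methyl: clearance outlook for compound 4

The compounds below may be only part of what the source reports. "The series", "measured", "known", "first", "only" and "open" are said of these compounds alone.

Measured so far in an ADME assay on microsomes from liver (Homo sapiens) for metabolic stability; a lower number here means slower removal, a higher number faster removal of the compound:
- compound 1, `Cc1cc2oc(N3CCC(C(=O)N[C@H]4CCC[C@H](CO)C4)CC3)nc2cc1Cl`: 28.3 mL/min/kg
- compound 2, `O=C(N[C@H]1CCC[C@H](CO)C1)C1CCN(c2nc3cc(Cl)c(-c4cccc(Cl)c4)cc3o2)CC1`: 55.8 mL/min/kg
- compound 3, `O=C(N[C@H]1CCC[C@H](CO)C1)C1CCN(c2nc3cc(Cl)c(C(F)(F)F)cc3o2)CC1`: 26.5 mL/min/kg

Compound 1 sits second highest of the three numbers; its nearest neighbour is compound 3, and the step of a 1.1-fold lower number from compound 1 to compound 3 (0.03 log units; within the scatter) stays within the scatter, while a 2.0-fold higher number from compound 1 to compound 2 (0.29 log units; within the scatter) sits at the edge of it. Between the other two, a 2.1-fold lower number from compound 2 to compound 3 (0.32 log units; beyond the scatter) is modest but beyond the scatter.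

Compound 4, `O=C(N[C@H]1CCC[C@H](CO)C1)C1CCN(c2nc3cc(Cl)c(-c4ccc(OC(F)(F)F)cc4)cc3o2)CC1`, arises from compound 1 by the change (4-(trifluoromethoxy)phenyl in place of methyl on an aromatic carbon). Within the data shown here, the only measured step of the same kind, an aromatic group entering in place of methyl on the same aromatic carbon, is a 2.0-fold higher number from compound 1 to compound 2 (0.29 log units; within the scatter); the steps of a 1.1-fold lower number from compound 1 to compound 3 (0.03 log units; within the scatter) and a 2.1-fold lower number from compound 2 to compound 3 (0.32 log units; beyond the scatter) bear on it only indirectly, by showing that the two smaller groups at this position give close numbers. Because a 2.0-fold higher number from compound 1 to compound 2 (0.29 log units; within the scatter) leans upward, compound 4 is expected to land near the level of compound 2, that is a step of a 1.8-fold higher number from compound 1 to compound 4 (0.25 log units; within the scatter), with the direction more secure than the size.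

The estimate for compound 4 in this assay is 50 mL/min/kg, within 28 mL/min/kg to 90 mL/min/kg.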

Compound 4, clearance: 50.8 mL/min/kg
Compound 4: middle estimate off by 1.0-fold (0.01 log units), on the low side, within the range that was stated.
By their numbers in this assay, from the lowest: compounds 3, 1, 4 and 2 (each within the scatter of the next, the first and the last beyond it).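

In this assay, the step of a 1.8-fold higher number from compound 1 to compound 4 (0.25 log units; within the scatter) and the step of a 1.9-fold higher number from compound 3 to compound 4 (0.28 log units; within the scatter) both stay within the scatter, so 4-(trifluoromethoxy)phenyl at this aromatic carbon cannot be told apart from either methyl or trifluoromethyl. The two aryl groups also give closely matching numbers, with a 1.1-fold lower number from compound 2 to compound 4 (0.04 log units; within the scatter), so changing the substituent on the phenyl ring and where it sits leaves no readable mark in this pair. No measurement on hand accounts for any of these steps.

Open, going by these compounds, is how a phenyl ring without a substituent, a pyridine ring, or an amine or carboxylic acid on the ring would read at this carbon. Also open, on these data alone, is whether the same steps would hold with the chloro group on the shared core replaced, for example by fluoro or nitrile.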